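The source may hold more compounds than are shown below. What is called first, only, known or untested is meant among the compounds shown, and "the series" means these compounds.

Compound 1 `N#Cc1ccc(-c2cnc(C(=O)CCCCCCc3ccccc3)o2)cc1`: 40 nM
Compound 2 `CNC(=O)c1cnc(C(=O)CCCCCCc2ccccc2)o1`: 7 nM
Compound 3 `CN(C)C(=O)c1cnc(C(=O)CCCCCCc2ccccc2)o1`: 2 nM

In an assay (Rattus norvegicus) for inhibition of Fatty-acid amide hydrolase 1 (Homo sapiens) (on this read-out higher numbers stand for weaker inhibition and lower numbers for stronger inhibition), compound 3 holds the lowest number of the three measured compounds. The steps of a 20-fold lower number from compound 1 to compound 3 (1.30 log units; beyond the scatter) and a 3.5-fold lower number from compound 2 to compound 3 (0.54 log units; beyond the scatter) both lead to it, and both go beyond the scatter. Compound 4 `CN1CCN(C(=O)c2cnc(C(=O)CCCCCCc3ccccc3)o2)CC1` carries the change (4-methylpiperazin-1-yl in place of dimethylamino on a carbonyl carbon). For the measured compounds named here, no measured step exchanges one amide amine for another; the nearest step, a 3.5-fold lower number from compound 2 to compound 3 (0.54 log units; beyond the scatter), changed only the substitution on the amide nitrogen and was modest. The change to compound 4 keeps the amide fully substituted, so the expectation is a step no larger than that one, in either direction, likely within the scatter: a 1.5-fold higher number from compound 3 to compound 4 (0.18 log units; within the scatter). Compound 4 is therefore expected to give about 3 nM, in the range 1 nM to 10 nM.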

Compound 4, inhibition constant: 80 nM
Estimate against measurement, compound 4: 27-fold (1.43 log units) below; measured number outside the range, above it.
By their numbers in this assay, from the lowest: compound 3; then compound 2; then compounds 1 and 4 (each within the scatter of the next).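

In this assay, a fully substituted amide on this carbonyl carbon does not by itself keep the number low: 4-methylpiperazin-1-yl in place of dimethylamino gives the largest step seen so far (a 40-fold higher number from compound 3 to compound 4 (1.60 log units; beyond the scatter)). The ring also loses out to the smaller methylamino group (an 11-fold higher number from compound 2 to compound 4 (1.06 log units; beyond the scatter)). Compound 4 no longer stands apart from the 4-cyanophenyl compound (a 2.0-fold higher number from compound 1 to compound 4 (0.30 log units; within the scatter)), a step within the scatter.

Nothing shown here explains this rise. On these data alone, whether a piperazine without the methyl, a morpholine or a piperidine on the same carbonyl carbon would behave like compound 4 stays open.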